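Pyridinyl for Bromophenyl in a Dienone Series

A few compounds are considered here, and "the series" means these few. Any claim that something is new, unique, unknown or untested is made for them only; others in the source may bear on it.

Of the compounds shown here, three sharing a cyclohexenyl dienone core have been measured in a functional assay on PC-3 cells (Homo sapiens) for cytotoxicity, read by sulforhodamine B assay, with a stated time of 48 h; a higher number here means a weaker inhibitor, a lower number a stronger inhibitor. Compound 1 `CC1=C(/C=C/C(=O)/C=C/c2ccc(Br)cc2)C(C)(C)CCC1` gives 18900 nM in this assay, the second highest of the three numbers. Compound 3 `COc1cc(/C=C/C(=O)/C=C/C2=C(C)CCCC2(C)C)cc(OC)c1OC` gives 32600 nM, and compound 2 `CC1=C(/C=C/C(=O)/C=C/c2ccccc2[N+](=O)[O-])C(C)(C)CCC1` gives 9500 nM; both of these values lie within the scatter of the value of compound 1, so no order among the three can be read from them. Compound 4 `CC1=C(/C=C/C(=O)/C=C/c2cccnc2)C(C)(C)CCC1` has not yet been measured in this assay. It differs from compound 1 by the change (pyridin-3-yl in place of 4-bromophenyl on a double-bonded chain carbon bound to a double-bonded chain carbon), that is, pyridin-3-yl in place of 4-bromophenyl on a double-bonded chain carbon bound to a double-bonded chain carbon. For the measured compounds named here, no measured pair in this set shows what such a change does, and the three measured values sit close together. The step from compound 1 to compound 4 is therefore expected to be a 1.2-fold higher number from compound 1 to compound 4 (0.07 log units; within the scatter), none beyond the scatter in either direction. Compound 4 is estimated at 22000 nM, with a range from 8000 nM to 60000 nM.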

Compound 4, half-maximal inhibitory concentration: 10200 nM
Beside the measured number, compound 4's estimate is 2.2-fold (0.33 log units) above it; the measured number falls inside the stated range.
By their numbers in this assay, from the lowest: compounds 2, 4, 1 and 3 (each within the scatter of the next, the first and the last beyond it).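

For the compounds shown here, this is the first step in the set that can be read at this position, on a double-bonded chain carbon bound to a double-bonded chain carbon: in this assay, pyridin-3-yl in place of 4-bromophenyl gives a 1.9-fold lower number from compound 1 to compound 4 (0.27 log units; within the scatter). The bromine-bearing carbon ring can thus give way to a six-membered aromatic ring with one nitrogen without the number leaving the scatter of that of compound 1. Nothing measured here bears on why the step has this size.

As far as these compounds go, what remains open is whether pyridin-2-yl or pyridin-4-yl would give a step of similar size, or whether an amine or a carboxylic acid on the phenyl ring would carry the number beyond the scatter. A single step also leaves open whether this exchange would give a similar result on any other core.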